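Thiosemicarbazone Series: From Chloro to Ethyl at Para Position

This account rests on a few compounds, and the source may have more. Where it says the series, first, only, none or still open, it means among the compounds named here.

Measured so far:
Compound 1, `CC(C)NC(=S)N/N=C1\C(=O)Nc2ccccc21`: 39300 nM
Compound 2, `O=C1Nc2ccccc2/C1=N/NC(=S)Nc1ccc(Cl)cc1`: 13400 nM

Both compounds were tested in a functional assay on KB 3-1 cells (Homo sapiens) for cytotoxicity, read by MTT assay, with a stated time of 72 h; on this read-out lower numbers stand for stronger inhibition and higher numbers for weaker inhibition. Compound 2 gives the lowest of the two numbers; its nearest neighbour is compound 1, and the step of a 2.9-fold lower number from compound 1 to compound 2 (0.47 log units; beyond the scatter) is a modest one, arising from 4-chlorophenyl in place of isopropyl on an amide-type nitrogen.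

Compound 3, `CCc1ccc(NC(=S)N/N=C2\C(=O)Nc3ccccc32)cc1`, has not yet been measured. It differs from compound 2 by ethyl in place of chloro on an aromatic carbon. Among the compounds with values here, no measured step concerns a change on that aromatic ring: the only step known, from compound 1 to compound 2, swaps the whole group on the nitrogen rather than a single substituent on the ring, so it bears on the new change only loosely. Within the data shown here, with no direct precedent, the expected step of a 1.0-fold lower number from compound 2 to compound 3 (0.01 log units; within the scatter) is none beyond the scatter. Compound 3 is therefore estimated at 13000 nM, within a range from 5500 nM to 31000 nM.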

Compound 3, half-maximal inhibitory concentration: 4050 nM
Compound 3: the middle estimate sits 3.2-fold (0.51 log units) above what was measured; the whole stated range lies above it.
By their numbers in this assay, from the lowest: compound 3; then compound 2; then compound 1.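

In this assay, the step (a 3.3-fold lower number from compound 2 to compound 3 (0.52 log units; beyond the scatter)) shows that this aromatic carbon, para to a large group, is sensitive to what it carries: ethyl in place of chloro, with the rest of the molecule unchanged, moves the number beyond the scatter. A change of one small substituent on the ring therefore counts as a modest step, and so does the exchange of the whole group on the nitrogen (a 2.9-fold lower number from compound 1 to compound 2 (0.47 log units; beyond the scatter)). No measurement shown here accounts for this step.

On these data alone, with only chloro and ethyl at this place, it remains open whether a longer chain such as propyl, or a different group such as an amine or methoxy, would lower the number further. As far as these compounds go, it is also open how a ring with only hydrogen there would compare with compound 2 and compound 3.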